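Swapping an Aryl Group for a Butyl Chain

A few compounds are considered here, and "the series" means these few. Any claim that something is new, unique, unknown or untested is made for them only; others in the source may bear on it.

Compound 1 `[O-][n+]1nc(NCOCc2ccc(Cl)cc2)[n+]([O-])c2ccccc21`: 1850 nM
Compound 2 `CCCCOCNc1n[n+]([O-])c2ccccc2[n+]1[O-]`: 3240 nM
Compound 3 `CCOCNc1n[n+]([O-])c2ccccc2[n+]1[O-]`: 4990 nM

Going by the values given here, in a functional assay on K562 cells (Homo sapiens) for cytotoxicity, read by MTT assay, with a stated time of 72 h (a lower number here means a stronger inhibitor, a higher number a weaker inhibitor), compound 1 has the lowest of the three numbers, though the step of a 1.8-fold higher number from compound 1 to compound 2 (0.24 log units; within the scatter) stays within the scatter; only the step of a 2.7-fold higher number from compound 1 to compound 3 (0.43 log units; beyond the scatter) is a modest rise beyond it. Compound 4 `CCCCCOCNc1n[n+]([O-])c2ccccc2[n+]1[O-]` differs from compound 1 in one place: butyl in place of 4-chlorophenyl on a saturated chain carbon bound to an oxygen on a saturated carbon. The two measured steps away from compound 1 replace the same group with shorter chains, and between those chains the step of a 1.5-fold higher number from compound 2 to compound 3 (0.19 log units; within the scatter) stayed within the scatter. Butyl extends the chain beyond propyl, so a number close to that of compound 2 is expected. Compound 4 is therefore estimated at 2700 nM (range 1400 nM to 5500 nM), an expected step of a 1.5-fold higher number from compound 1 to compound 4 (0.16 log units; within the scatter), within the scatter.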

Compound 4, half-maximal inhibitory concentration: 3300 nM
Estimate against measurement, compound 4: 1.2-fold (0.09 log units) below; low and high end bracket the measured number.
By their numbers in this assay, from the lowest: compounds 1, 2, 4 and 3 (each within the scatter of the next, the first and the last beyond it).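

In this assay, butyl in place of 4-chlorophenyl gives a 1.8-fold higher number from compound 1 to compound 4 (0.25 log units; within the scatter) and so keeps compound 4 within the scatter of the compound with the aromatic ring. Among the plain chains, a 1.5-fold lower number from compound 3 to compound 4 (0.18 log units; within the scatter) and a 1.0-fold higher number from compound 2 to compound 4 (0.01 log units; within the scatter) both stay within the scatter too, so these three chain lengths cannot be told apart. No measurement here explains this result. Still open, as far as these compounds go, is whether a much longer chain, such as octyl, would read the same in this place. An amine on the chain is equally untested by these compounds.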